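Swapping chloro for hydrogen on compound 2

A few compounds are considered here, and "the series" means these few. Any claim that something is new, unique, unknown or untested is made for them only; others in the source may bear on it.

In a functional assay on A549 cells (Homo sapiens) for antiproliferative activity, read by MTT assay, with a stated time of 72 h (a higher number here means a weaker inhibitor, a lower number a stronger inhibitor), compound 1 `N=C(NS(=O)(=O)c1ccccc1)N1CCN(c2cc3c(cc2F)c(=O)c(C(=O)O)cn3C2CC2)CC1` gives 71 nM and compound 2 `CCn1cc(C(=O)O)c(=O)c2cc(F)c(N3CCN(C(=N)NS(=O)(=O)c4ccccc4Cl)CC3)cc21` gives 71 nM. Compound 2 therefore stands level with compound 1, within the usual scatter of repeated measurements. Compound 3 `CCn1cc(C(=O)O)c(=O)c2cc(F)c(N3CCN(C(=N)NS(=O)(=O)c4ccccc4)CC3)cc21` is compound 2 with hydrogen in place of chloro on an aromatic carbon, ortho to a large group: hydrogen in place of chloro on an aromatic carbon. Within the data shown here, no measured pair shows this change alone, so its size cannot be read directly from the data. Compound 1 carries no chloro on its phenylsulfonyl group and still gives 71 nM, so no large shift is expected in this assay, in either direction. The expected 1.0-fold lower number from compound 2 to compound 3 (0.01 log units; within the scatter) is small and stays within the scatter. For compound 3 the estimated value is 70 nM, with an expected range of 25 nM to 200 nM.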

Compound 3, half-maximal inhibitory concentration: 71 nM
Estimate against measurement, compound 3: 1.0-fold (0.01 log units) below; the range from low to high includes it.
By their numbers in this assay, from the lowest: compounds 1, 2 and 3 (each within the scatter of the next).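

In this assay, among these compounds, there is no change at the digits printed from compound 2 to compound 3 (within the scatter), which gives the first direct reading of this change: on this aromatic carbon, chloro and hydrogen cannot be told apart. The new compound also links a second place, the aromatic nitrogen, where ethyl in place of cyclopropyl likewise leaves no change at the digits printed from compound 1 to compound 3 (within the scatter). Neither single change moves the number beyond the scatter, and no measurement here gives a reason for this.

As far as these compounds go, it remains open whether the aromatic carbon tolerates every group, since a methoxy, an amine or a carboxylic acid in place of the chloro could give a different result. A longer chain than ethyl on the aromatic nitrogen is equally untested by the compounds shown, so how far that place stays flat is also unknown.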